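Short chains on the double-bonded nitrogen of the shared core

The source may report more compounds than this note shows. Statements on the series, on what has been measured and on what is new or still open speak of the compounds shown alone.

Compound 3 `C/C(=N\CC1CCCCC1)c1c(O)c2ccccc2[nH]c1=O` carries cyclohexylmethyl on the double-bonded nitrogen of the shared core. In an assay on isolated protein for inhibition of myosin-2 (Bos taurus), read by spectrophotometry, with a stated time of 24 min (a lower number here means a stronger inhibitor, a higher number a weaker inhibitor), compound 3 reaches only the limit of the measurement, >= 100000 nM. Compound 1 `CCC/N=C(\C)c1c(O)c2ccccc2[nH]c1=O` in this assay likewise stops at the limit, >= 100000 nM. Compound 2 `C/C(=N\CCO)c1c(O)c2ccccc2[nH]c1=O` in this assay also sits at the limit, >= 100000 nM. The three measured steps, a step that the two limits leave unreadable from compound 1 to compound 2, a step that the two limits leave unreadable from compound 1 to compound 3 and a step that the two limits leave unreadable from compound 2 to compound 3, give no readable size, as the limit of >= 100000 nM in this assay, at which 3 of the 3 values shown sit, shows: every value of the series is a limit rather than a number.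

Compound 4 `CCCC/N=C(\C)c1c(O)c2ccccc2[nH]c1=O` is not yet measured; it differs from compound 3 by propyl in place of cyclohexyl on a saturated chain carbon bound to a double-bonded nitrogen. Within the data shown here, no measured step bears on this change with a readable size, since each step starts and ends at the limit. The expectation for compound 4 in this assay is therefore a step of a number no higher from compound 3 to compound 4 (the limit leaves the size open), with no change beyond the scatter expected. Compound 4 is estimated at 100000 nM, within 40000 nM to 300000 nM, and is expected most likely to be reported again only as a limit.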

Compound 4, half-maximal inhibitory concentration: >= 100000 nM
Compound 4 was reported as a limit; the forecaster's own chance of this, stated with the estimate: 85%; the middle value sits exactly at the limit.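

Compound 4, like compound 1, compound 2 and compound 3, gives only a limit in this assay, so none of the steps among them can be read: the limit of >= 100000 nM in this assay, at which 4 of the 4 values shown sit.

The compounds shown leave open whether any chain on the double-bonded nitrogen of the shared core gives a readable number in this assay.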